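The source may report more compounds than this note shows. Statements on the series, on what has been measured and on what is new or still open speak of the compounds shown alone.

Compound 1, `CC(C)c1ccccc1OS(=O)(=O)c1ccc(NC(=O)CCCl)cc1`, gives 6500 nM in a functional assay on HT-1080 cells (Homo sapiens) for antiproliferative activity, read by sulforhodamine B assay, with a stated time of 48 h; a higher number here means a weaker inhibitor, a lower number a stronger inhibitor.
Compound 2, `CC(C)c1ccccc1OS(=O)(=O)c1ccc(NC(=O)CCCCl)cc1`, gives 3800 nM in this assay.
Compound 3, `CCCCCNC(=O)Nc1ccc(S(=O)(=O)Oc2ccccc2C(C)C)cc1`, gives 4700 nM in this assay.

Compound 3 stands second highest of these three numbers, and all three lie close together: a 1.2-fold higher number from compound 2 to compound 3 (0.09 log units; within the scatter), and a 1.4-fold lower number from compound 1 to compound 3 (0.14 log units; within the scatter). Compound 4, `CC(C)c1ccccc1OS(=O)(=O)c1ccc(NC(=O)NCC2CCCC2)cc1`, differs from compound 3 by cyclopentyl in place of butyl on a saturated chain carbon bound to an amide-type nitrogen. Among the compounds with values here, no measured step touches this part of the chain; the nearest comparisons are the exchanges on the carbonyl carbon, a 1.4-fold lower number from compound 1 to compound 3 (0.14 log units; within the scatter) and a 1.2-fold higher number from compound 2 to compound 3 (0.09 log units; within the scatter), together with a 1.7-fold lower number from compound 1 to compound 2 (0.23 log units; within the scatter), all within the scatter. On that basis no step beyond the scatter is expected in this assay in either direction. Compound 4 is therefore estimated at 4500 nM, with a range from 2000 nM to 10000 nM. The step this estimate implies is expected to be a 1.0-fold lower number from compound 3 to compound 4 (0.02 log units; within the scatter).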

Compound 4, half-maximal inhibitory concentration: 6000 nM
For compound 4 the middle estimate is 1.3-fold (0.12 log units) below the measured one; the range from low to high includes it.
By their numbers in this assay, from the lowest: compounds 2, 3, 4 and 1 (each within the scatter of the next).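

In this assay, cyclopentyl in place of butyl on a saturated chain carbon bound to an amide-type nitrogen stays within the scatter (a 1.3-fold higher number from compound 3 to compound 4 (0.11 log units; within the scatter)), so this position now has a ring-bearing example alongside the open chain. (Cyclopentylmethyl)amino on the carbonyl carbon also stays within the scatter of both chloroalkyl groups (a 1.6-fold higher number from compound 2 to compound 4 (0.20 log units; within the scatter); a 1.1-fold lower number from compound 1 to compound 4 (0.03 log units; within the scatter)). No evidence is available that bears on this result.

From the compounds shown here alone, whether cyclohexyl, phenyl or a piperidine ring at this position would also stay within the scatter remains open. So does the effect of a carboxylic acid or an amine at the chain end.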